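The compounds below may be only part of what the source reports. "The series", "measured", "known", "first", "only" and "open" are said of these compounds alone.

In a functional assay on A549 cells (Homo sapiens) for antiproliferative activity, read by MTT assay, with a stated time of 48 h (on this read-out higher numbers stand for weaker inhibition and lower numbers for stronger inhibition), compound 1 `N#CC1=C(N)Oc2c(c3nc4ccccc4nc3c3ccccc23)C12C(=O)N(Cc1cnnn1-c1ccc(F)c(Cl)c1)c1ccccc12` gives only a limit of the assay, > 50000 nM. Compound 2 `N#CC1=C(N)Oc2c(c3nc4ccccc4nc3c3ccccc23)C12C(=O)N(Cc1cnnn1-c1ccc(Cl)c(Cl)c1)c1ccccc12` likewise gives only a limit, > 50000 nM. Within the data shown here, the one measured step, a step that the two limits leave unreadable from compound 1 to compound 2, is therefore not readable in size. Compound 3 `N#CC1=C(N)Oc2c(N)cc3nc4ccccc4nc3c2C12C(=O)N(Cc1cnnn1-c1ccc([N+](=O)[O-])cc1)c1ccccc12` also stands at a limit, > 50000 nM. Every value shown sits at that same limit (the limit of > 50000 nM in this assay, at which 3 of the 3 values shown sit), so compound 3 cannot be ranked against the others. Compound 4 `Cc1cc(C)c(-n2nncc2CN2C(=O)C3(C(C#N)=C(N)Oc4c(N)cc5nc6ccccc6nc5c43)c3ccccc32)c(C)c1` differs from compound 3 by 2,4,6-trimethylphenyl in place of 4-nitrophenyl on an aromatic nitrogen. Among the measured compounds shown here, no measured step bears on this change, and the only step available is unreadable. Compound 4 is therefore expected to give 50000 nM, with a range from 20000 nM to 150000 nM. This amounts to an expected step of a number no higher from compound 3 to compound 4 (the limit leaves the size open), with no direction beyond the scatter.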

Compound 4, half-maximal inhibitory concentration: 12700 nM
Estimate against measurement, compound 4: 3.9-fold (0.60 log units) above; measured number outside the range, below it.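

In this assay, the group on the aromatic nitrogen of the five-membered ring proves able to change the result: 2,4,6-trimethylphenyl in place of 4-nitrophenyl gives an at least 3.9-fold lower number from compound 3 to compound 4 (0.59 log units; beyond the scatter). This is the only change shown with a readable effect, and compound 4 is the only compound with a measured number rather than a limit. The full size of the step stays open, since its starting point is only a limit: the limit of > 50000 nM in this assay, at which 3 of the 4 values shown sit.

Going by these compounds, it remains open whether losing the nitro group or gaining the methyl groups matters; plain phenyl or 4-aminophenyl could help separate the two. Whether 2,4,6-trimethylphenyl would also lower the number on the core of compound 1 is open too.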